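Swapping the Pyridyl Attachment Point: Expected Permeability of Compound 4

A few compounds are considered here, and "the series" means these few. Any claim that something is new, unique, unknown or untested is made for them only; others in the source may bear on it.

Compound 3 `O=C(Nc1cccc(-c2nc3ccccc3s2)c1)c1cnccc1Cl` stands highest of the three compounds measured in an ADME assay for permeability, using PAMPA (on this read-out higher numbers stand for higher permeability and lower numbers for lower permeability), where compound 3 gives 732 10^-6 cm/s. Compound 2 `O=C(CCl)Nc1cccc(-c2nc3ccccc3s2)c1` sits nearest, and compound 2 gives 660 10^-6 cm/s, a gap within the scatter: a 1.1-fold higher number from compound 2 to compound 3 (0.04 log units; within the scatter). Compound 1 `O=C(O)/C=C/C(=O)Nc1cccc(-c2nc3ccccc3s2)c1` lies furthest, since compound 1 gives 4 10^-6 cm/s; the steps of a 170-fold higher number from compound 1 to compound 2 (2.22 log units; beyond the scatter) and a 180-fold higher number from compound 1 to compound 3 (2.26 log units; beyond the scatter) were both large. Compound 4 `O=C(Nc1cccc(-c2nc3ccccc3s2)c1)c1ccncc1Cl` differs from compound 3 only in the group on the carbonyl carbon: 3-chloropyridin-4-yl in place of 4-chloropyridin-3-yl on a carbonyl carbon. Going by the values given here, no measured pair tests this exact rearrangement; the one step that exchanged the group on that carbon, a 1.1-fold higher number from compound 2 to compound 3 (0.04 log units; within the scatter), stayed within the scatter, so no step beyond the scatter is expected in this assay. Compound 4 is therefore expected to give about 700 10^-6 cm/s, between 350 10^-6 cm/s and 1400 10^-6 cm/s. The expected step is a 1.0-fold lower number from compound 3 to compound 4 (0.02 log units; within the scatter).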

Compound 4, apparent permeability: 563 10^-6 cm/s
Compound 4: the middle estimate sits 1.2-fold (0.09 log units) above what was measured; the range from low to high includes it.
By their numbers in this assay, from the lowest: compound 1; then compounds 4, 2 and 3 (each within the scatter of the next).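

Exchanging 4-chloropyridin-3-yl for 3-chloropyridin-4-yl on a carbonyl carbon, two groups with the same atoms joined differently, gave a step in this assay that stayed small (a 1.3-fold lower number from compound 3 to compound 4 (0.11 log units; within the scatter)), and the step from the chloromethyl compound did too (a 1.2-fold lower number from compound 2 to compound 4 (0.07 log units; within the scatter)). Only the 2-carboxyethenyl group stands apart among the groups shown, with the gap again large (a 140-fold higher number from compound 1 to compound 4 (2.15 log units; beyond the scatter)). Nothing available explains these readings. As far as these compounds go, it remains open whether an amine or a longer alkyl chain on this carbonyl carbon would read near compound 2 or near compound 1.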